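This account rests on a few compounds, and the source may have more. Where it says the series, first, only, none or still open, it means among the compounds named here.

Compound 1 `COc1cc2c(Oc3ccc(NC(=O)c4nn(-c5ccccc5C(F)(F)F)c(=O)cc4C)cc3F)ccnc2cc1OCCCN1CCN(C)CC1` — 170 nM
Compound 2 `COc1cc2c(Oc3ccc(NC(=O)c4nn(-c5cccc(F)c5)c(=O)cc4C)cc3F)ccnc2cc1OCCCN1CCN(C)CC1` — 150 nM
Compound 3 `COc1ccc(-n2nc(C(=O)Nc3ccc(Oc4ccnc5cc(OCCCN6CCN(C)CC6)c(OC)cc45)c(F)c3)c(C)cc2=O)cc1` — 2200 nM

These three compounds share one core and differ only in the aryl group on an aromatic nitrogen. In a functional assay on A549 cells (Homo sapiens) for inhibition, read by MTT assay, with a stated time of 72 h (a higher number here means a weaker inhibitor, a lower number a stronger inhibitor), compound 3 gives the highest number of the three: a 13-fold higher number from compound 1 to compound 3 (1.11 log units; beyond the scatter) and a 15-fold higher number from compound 2 to compound 3 (1.17 log units; beyond the scatter), both beyond the scatter, whereas a 1.1-fold lower number from compound 1 to compound 2 (0.05 log units; within the scatter). Compound 4 `COc1cc2c(Oc3ccc(NC(=O)c4nn(-c5ccc(F)c(F)c5)c(=O)cc4C)cc3F)ccnc2cc1OCCCN1CCN(C)CC1` has not been measured; it differs from compound 3 in one place: 3,4-difluorophenyl in place of 4-methoxyphenyl on an aromatic nitrogen. The two large steps that reach compound 3 bear on this change, as both exchange the 4-methoxyphenyl for a different aryl group. The 3,4-difluorophenyl of compound 4 is close to the 3-fluorophenyl of compound 2, which gives 150 nM in this assay. A large step downward is therefore expected for compound 4, an 8.8-fold lower number from compound 3 to compound 4 (0.94 log units; beyond the scatter). Compound 4 is estimated at 250 nM, with a range of 100 nM to 900 nM.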

Compound 4, half-maximal inhibitory concentration: 130 nM
Estimate against measurement, compound 4: 1.9-fold (0.28 log units) above, and the stated range covers the measured number.
By their numbers in this assay, from the lowest: compounds 4, 2 and 1 (each within the scatter of the next); then compound 3.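

In this assay a third aryl group now stands apart from the 4-methoxyphenyl of compound 3, again by a large step (a 17-fold lower number from compound 3 to compound 4 (1.23 log units; beyond the scatter)). The added fluoro on an aromatic carbon gives a step within the scatter (a 1.2-fold lower number from compound 2 to compound 4 (0.06 log units; within the scatter)), and so does the exchange of 2-(trifluoromethyl)phenyl for 3,4-difluorophenyl (a 1.3-fold lower number from compound 1 to compound 4 (0.12 log units; within the scatter)), so the three fluorine-bearing aryl groups cannot be told apart and only the 4-methoxyphenyl differs. Nothing available explains this gap. Open, as far as these compounds go, is whether a 3-methoxyphenyl or a 4-fluorophenyl would read like compound 3 or like compound 4, and how an aryl group carrying an amine or a carboxylic acid would read.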